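Dropping one chlorine from a dichloropurine cytotoxin

This account rests on a few compounds, and the source may have more. Where it says the series, first, only, none or still open, it means among the compounds named here.

Of the compounds shown here, two have been tested in a functional assay on OVCAR-8 cells (Homo sapiens) for cytotoxicity, read by sulforhodamine B assay, with a stated time of 48 h; on this read-out lower numbers stand for higher toxicity in this test and higher numbers for lower toxicity in this test. Compound 1 `ClCc1ccc(Cn2cnc3c(Cl)ncnc32)cc1` carries a single chloro on its fused core and a chloromethyl group placed differently on the benzyl ring; in this assay compound 1 gives 64600 nM. Compound 2 `ClCc1ccccc1Cn1cnc2c(Cl)nc(Cl)nc21` carries two chloro groups on the same core, and in this assay compound 2 gives 6450 nM, the lowest of the two numbers and clearly separated from compound 1, whose number lies beyond the scatter above it. Because compound 1 and compound 2 differ in more than one place, their gap cannot be assigned to a single change.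

Compound 3 `ClCc1ccccc1Cn1cnc2c(Cl)ncnc21` is the next step: from compound 2, (hydrogen in place of chloro on an aromatic carbon). Among the compounds with values here, no directly comparable pair has been measured, so the size of this step is open. Within the data shown here, the only hint is that compound 1, which also lacks that chloro, sits higher, so a moderate rise beyond the scatter is expected, with the step of a 3.1-fold higher number from compound 2 to compound 3 (0.49 log units; beyond the scatter). Compound 3 is therefore estimated at 20000 nM, in a range from 6000 nM to 70000 nM.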

Compound 3, concentration lethal to 50% of the cells: 20400 nM
The estimate for compound 3 lay 1.0-fold (0.01 log units) below the measured number; the range from low to high includes it.
By their numbers in this assay, from the lowest: compound 2; then compound 3; then compound 1.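

In this assay, within the data shown here, the first comparison that changes one place only is a 3.2-fold higher number from compound 2 to compound 3 (0.50 log units; beyond the scatter), where hydrogen replaces the chloro on the aromatic carbon between two ring nitrogen atoms while the other chloro and the chloromethyl group stay as they were. This isolates that single chloro: its presence goes with a lower number, meaning higher toxicity in this test, and the opening comparison could not show this because compound 1 also has its chloromethyl group placed differently. The step is modest but lies beyond the scatter, and no measurement shown here accounts for it.

The compounds shown hold only chloro or hydrogen at this position, so what an amine or a methoxy group there would do remains open. From the compounds shown here alone, whether the step would keep its size with the chloromethyl group placed as in compound 1 also remains open.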